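Dropping a Methyl from a Poorly Soluble Core

The compounds below may be only part of what the source reports. "The series", "measured", "known", "first", "only" and "open" are said of these compounds alone.

Compound 3 `COc1ccc(-c2c(C)nn3c(NCc4ccccn4)cc(C)nc23)cc1` was measured in a physicochemical assay for solubility, read by HPLC, using the shake flask method, measured as kinetic solubility, with a stated time of 2 h, at pH 7.4; a higher number here means a more soluble compound, a lower number a less soluble compound. In this assay compound 3 gives < 5000 nM, which is a limit of the assay rather than a number. Compound 1 `Cc1ccc(-c2cnn3c(NCc4ccccn4)cc(C)nc23)cc1` sits at the same kind of value: in this assay compound 1 gives < 5000 nM, again only a limit. Among the compounds with values here, compound 2 `Cc1cc(NCc2ccccn2)n2ncc(Br)c2n1` gives 89300 nM in this assay, and the only measured step, an at least 17-fold higher number from compound 1 to compound 2 (1.25 log units; beyond the scatter), swaps out the whole aromatic group for a bromine. Compound 4 `COc1ccc(-c2cnn3c(NCc4ccccn4)cc(C)nc23)cc1` differs from compound 3 by hydrogen in place of methyl on an aromatic carbon. Within the data shown here, no measured step touches this methyl, and a single carbon is a far smaller change than the one recorded step. The expected step is therefore a step that the limit leaves unreadable from compound 3 to compound 4, nothing beyond the scatter. Compound 4 is estimated at 3000 nM, within 1000 nM to 8000 nM, and most likely again reported only as a limit.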

Compound 4, solubility: < 5000 nM
Compound 4: only a limit was reported; the forecaster's own chance of this, stated with the estimate: 75%; the middle value lies beyond the limit too.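

Compound 4, with hydrogen in place of the methyl, is also reported only as a limit of the assay, so this position yields no readable number. Within the data shown here, the steps from compound 3 to compound 4 and from compound 1 to compound 4 cannot be read, because each pair ends at the same limit: the limit of < 5000 nM in this assay, at which 3 of the 4 values shown sit. The only readable step is an at least 17-fold lower number from compound 2 to compound 4 (1.25 log units; beyond the scatter), with 4-methoxyphenyl in place of bromo, and it is large.

From the compounds shown here alone, how far compounds 1, 3 and 4 lie under that limit stays open, so any effect of the methyl remains unknown. Also open, going by these compounds, is whether an amine or a carboxylic acid on the 4-methoxyphenyl group would bring a value above the limit in this assay.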